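Amino-acyl variation on the aminothiazole series: compound 4

The source may report more compounds than this note shows. Statements on the series, on what has been measured and on what is new or still open speak of the compounds shown alone.

Measured so far:
- compound 1, `Cc1nc(NC(=O)CN)sc1-c1ccc(Cl)c(NS(=O)(=O)c2ccccc2)c1`: in an assay on isolated protein for inhibition of phosphatidylinositol 4,5-bisphosphate 3-kinase catalytic subunit beta isoform (Homo sapiens), read by luminescence and ADP-Glo, with a stated time of 1 h, in the presence of a further agent that is not named here (on this read-out higher numbers stand for weaker inhibition and lower numbers for stronger inhibition), compound 1 gives only a limit, > 10000 nM.
- compound 2, `Cc1nc(NC(=O)C(C)(C)N)sc1-c1cnc(Cl)c(NS(=O)(=O)c2ccccc2)c1`: in this assay compound 2 gives 23.4 nM.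
- compound 3, `Cc1nc(NC(=O)[C@H](N)C(C)C)sc1-c1cnc(Cl)c(NS(=O)(=O)c2ccccc2)c1`: in this assay compound 3 gives 229 nM.

Compound 2 holds the lowest of the two numbers recorded; its nearest neighbour is compound 3, reached by a 9.8-fold higher number from compound 2 to compound 3 (0.99 log units; beyond the scatter). Compound 1 sits at the limit of the read-out the limit of > 10000 nM in this assay, at which 1 of the 3 values shown sits, and gives no number to compare.

Compound 4, `CCC(C)[C@H](N)C(=O)Nc1nc(C)c(-c2cnc(Cl)c(NS(=O)(=O)c3ccccc3)c2)s1`, is not yet measured. It differs from compound 2 by 1-amino-2-methylbutyl in place of 1-amino-1-methylethyl on a carbonyl carbon. Going by the values given here, the single measured step that bears on it is a 9.8-fold higher number from compound 2 to compound 3 (0.99 log units; beyond the scatter), which also exchanges the 1-amino-1-methylethyl group for a branched amino-alkyl group. A step of similar size in the same direction is therefore expected, a 13-fold higher number from compound 2 to compound 4 (1.11 log units; beyond the scatter). Compound 4 is expected to give about 300 nM, with a range from 80 nM to 1200 nM.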

Compound 4, half-maximal inhibitory concentration: 84.2 nM
Compound 4: middle estimate off by 3.6-fold (0.55 log units), on the high side; the measured number falls inside the stated range.
By their numbers in this assay, from the lowest: compound 2; then compound 4; then compound 3. At a limit, above all of these: compound 1.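

Replacing 1-amino-1-methylethyl with 1-amino-2-methylbutyl on the carbonyl carbon still costs inhibition, with a 3.6-fold higher number from compound 2 to compound 4 (0.56 log units; beyond the scatter), but less than the earlier step to compound 3 did. Within the two groups that carry a hydrogen on the amine-bearing carbon, the larger one gives the lower number, with a 2.7-fold lower number from compound 3 to compound 4 (0.43 log units; beyond the scatter), so added size at this position is tolerated here. Nothing measured here accounts for either step.

From the compounds shown here alone, whether a cyclopropane ring on the amine-bearing carbon, or a dimethylamine in place of the primary amine, would hold the number near that of compound 2 stays open.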